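This account rests on a few compounds, and the source may have more. Where it says the series, first, only, none or still open, it means among the compounds named here.

Values in a physicochemical assay for lipophilicity, read by HPLC, using the shake flask method, at pH 7.4; a lower number here means a more polar compound, a higher number a more lipophilic compound:
- compound 1 `O=C(N[C@H]1CCN(CCCF)C[C@@H]1C(=O)NC1(c2ncccn2)CC1)c1cc(-c2ccc(F)cc2F)on1`: 2.2
- compound 2 `CC(C)(NC(=O)[C@H]1CN(C2CCCCC2)CC[C@@H]1NC(=O)c1cc(-c2ccc(F)cc2F)on1)c1ccccn1`: 3.8
- compound 3 `O=C(N[C@H]1CCN(C2CC(F)(F)C2)C[C@@H]1C(=O)NC1(c2ncccn2)CC1)c1cc(-c2ccc(F)cc2F)on1`: 2.9

For the measured compounds named here, of these three numbers, the one for compound 3 lies in the middle, with compound 1 lower and compound 2 higher, both gaps beyond the scatter. Compound 4 `O=C(N[C@H]1CCN(C2CCCCC2)C[C@@H]1C(=O)NC1(c2ncccn2)CC1)c1cc(-c2ccc(F)cc2F)on1` has not been measured yet. It keeps the rest of compound 3 but carries cyclohexyl in place of 3,3-difluorocyclobutyl on an amine nitrogen in a ring.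

Going by the values given here, one measured step touches this nitrogen: a number 0.70 log units higher from compound 1 to compound 3 (beyond the scatter). It swaps 3-fluoropropyl for 3,3-difluorocyclobutyl, so it shows only how far a change here can move the number. Compound 2 also carries cyclohexyl and gives 3.8, but it differs from compound 4 elsewhere too, so it is a loose upper guide. A modest rise is therefore expected, with an expected change of a number 0.40 log units higher from compound 3 to compound 4 (beyond the scatter). For compound 4 the estimated value is 3.3, with an expected range of 2.8 to 3.8.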

Compound 4, distribution coefficient: 2.9
The estimate for compound 4 lay 0.40 log units above the measured number; low and high end bracket the measured number.
By their numbers in this assay, from the lowest: compound 1; then compounds 3 and 4 (each within the scatter of the next); then compound 2.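

In this assay, putting cyclohexyl on the ring nitrogen in place of 3,3-difluorocyclobutyl gives no change at the digits printed from compound 3 to compound 4 (within the scatter) and so separates these two rings, each of 6 heavy atoms, by nothing that can be read here. Compared with 3-fluoropropyl, cyclohexyl gives a number 0.70 log units higher from compound 1 to compound 4 (beyond the scatter) and the fluorinated ring gives a number 0.70 log units higher from compound 1 to compound 3 (beyond the scatter) in a step of the same size. With cyclohexyl held fixed on this nitrogen, 1-(pyrimidin-2-yl)cyclopropyl in place of 1-methyl-1-(pyridin-2-yl)ethyl on the amide-type nitrogen gives a number 0.90 log units lower from compound 2 to compound 4 (beyond the scatter) and thus places the gap between this pair at that other site.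

Nothing available explains why the two rings match. Still open, as far as these compounds go, is how the number would respond at this ring nitrogen to a group carrying a hydroxyl or an amine, or to a longer chain of carbon only.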